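Notes on the aroylhydrazone series: nitro replaces chloro

The source may report more compounds than this note shows. Statements on the series, on what has been measured and on what is new or still open speak of the compounds shown alone.

Two members of the series carry numbers in an ADME assay on cells (Mus musculus, strain BALB/C) for cytotoxicity, read by MTT assay, with a stated time of 24 h; on this read-out lower numbers stand for higher toxicity in this test and higher numbers for lower toxicity in this test. Compound 1 `Cc1ccc(C(=O)N/N=C/c2ccccc2O)c(O)c1` gives 761000 nM; compound 2 `Cc1ccc(C(=O)N/N=C/c2ccc(Cl)cc2)c(O)c1` gives 116000 nM. Of the two, compound 2 stands at the lower number, and compound 1 sits above it by a margin beyond the scatter. Within the data shown here, no pair differing in one place has been measured, so the size of a single change in this assay is not yet known from the series itself.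

Compound 3 `Cc1ccc(C(=O)N/N=C/c2ccc([N+](=O)[O-])cc2)c(O)c1` is the next entry. It differs from compound 2 in one place: nitro in place of chloro on an aromatic carbon. Without a measured step to draw on, the expectation in this assay is a small change, if any, with the number for compound 3 estimated to fall somewhat under that of compound 2, within the scatter. Compound 3 is expected to give about 90000 nM, within a range of 30000 nM to 300000 nM, which means an estimated step of a 1.3-fold lower number from compound 2 to compound 3 (0.11 log units; within the scatter).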

Compound 3, half-maximal cytotoxic concentration: 734000 nM
Compound 3: the middle estimate sits 8.2-fold (0.91 log units) below what was measured; measured number above the stated range.
By their numbers in this assay, from the lowest: compound 2; then compounds 3 and 1 (each within the scatter of the next).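

Among these compounds, this is the first single-place step: in this assay, nitro in place of chloro on an aromatic carbon, para to a large group, gives a 6.3-fold higher number from compound 2 to compound 3 (0.80 log units; beyond the scatter) at this position. The position is therefore not silent in this assay, since one substituent swap there moves the number beyond the scatter, toward lower toxicity in this test. Nothing at hand bears on why this swap has an effect of this size.

Going by these compounds, only chloro and nitro are compared at this position, so it remains open whether the step reflects something particular to chloro or to nitro. An amine, a methoxy group or a carboxylic acid at the same place would show whether other groups side with compound 2 or with compound 3.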